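Benzyl to 4-methylphenyl: estimating compound 4

The source may hold more compounds than are shown below. What is called first, only, known or untested is meant among the compounds shown, and "the series" means these compounds.

Values measured in an ADME assay on L02 cells (Homo sapiens) for inhibition, read by CCK-8 assay, with a stated time of 48 h; a higher number here means a weaker inhibitor of growth, a lower number a stronger inhibitor of growth:
- Compound 1 `CCN1CCN(c2ccc(Nc3ncc(Cl)c(Nc4ccccc4C)n3)nc2)CC1`: > 100000 nM
- Compound 2 `CCN1CCN(c2ccc(Nc3ncc(Cl)c(Nc4ccccc4C)n3)cc2)CC1`: 970 nM
- Compound 3 `CN1CCN(c2ccc(Nc3ncc(Cl)c(NCc4ccccc4)n3)nc2)CC1`: 20300 nM

Among the compounds with values here, only two of these values are true numbers. Of those two, compound 3 at 20300 nM is the higher, and compound 2 at 970 nM lies lower by a gap beyond the usual scatter. So compound 3 is the weaker inhibitor of growth of this pair in this assay.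

Compound 4 `Cc1ccc(Nc2nc(Nc3ccc(N4CCN(C)CC4)cn3)ncc2Cl)cc1` has not yet been measured. It has the same atoms as compound 3, joined differently: 4-methylphenyl in place of benzyl on a nitrogen on an aromatic ring. In words, 4-methylphenyl stands in place of benzyl on a nitrogen on an aromatic ring.

Within the data shown here, no two measured compounds differ in one place only, so the size of this change cannot be read directly. Compound 2 also carries a methylphenyl group on that nitrogen and gives 970 nM. Compound 1 carries one too, and its > 100000 nM is a limit of the assay and not a number.

These two point in opposite directions, so no step beyond the scatter is expected in this assay, though the uncertainty is wide. The estimated change is a 1.2-fold higher number from compound 3 to compound 4 (0.09 log units; within the scatter). For compound 4 the expected value is 25000 nM, with an estimated range from 5000 nM to 100000 nM.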

Compound 4, concentration for 50% growth inhibition: 13900 nM
Estimate against measurement, compound 4: 1.8-fold (0.25 log units) above; measured number inside the range.
By their numbers in this assay, from the lowest: compound 2; then compounds 4 and 3 (each within the scatter of the next). At a limit, above all of these: compound 1.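

Compounds 3 and 4 are the first pair shown that differ in one place only, so the change on this nitrogen can now be read directly in this assay: a 1.5-fold lower number from compound 3 to compound 4 (0.16 log units; within the scatter). Both groups carry the same atoms and one six-membered aromatic ring of carbon only, and the step shows that joining those atoms as 4-methylphenyl and not as benzyl makes no difference beyond the scatter on this shared core. The earlier compounds shown here could not show this, as each differs from the others in more than one place, so this position had no measured step until now.

Compound 1 gives > 100000 nM, which is a limit of the assay and not a number, so it cannot size any step here: the limit of > 100000 nM in this assay, at which 1 of the 4 values shown sits.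

Still open, on these data alone, is whether a group of another kind on this nitrogen, such as cyclohexyl, or a carboxylic acid or an amine in place of the methyl on the 4-methylphenyl group, would move the number beyond the scatter, and compound 2 cannot answer this, as it differs from compound 3 and compound 4 in more than one place.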